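Moving a methyl group around a ring in a Vero cytotoxicity test

The source may report more compounds than this note shows. Statements on the series, on what has been measured and on what is new or still open speak of the compounds shown alone.

The three compounds already tested share a common core, and compound 1 `Cc1ccccc1C(=O)/C=C1\Nc2ccccc2OC1=O` carries a 2-methylphenyl group on its carbonyl carbon. In an ADME assay on Vero cells (Chlorocebus sabaeus) for cytotoxicity, read by MTT assay, with a stated time of 72 h (on this read-out lower numbers stand for higher toxicity in this test and higher numbers for lower toxicity in this test), compound 1 gives only a limit, reported as > 1790000 nM, not a measured number. This is the single value the set provides, as shown by the limit of > 1790000 nM in this assay, at which 1 of the 3 values shown sits. Compound 2 `CN1C(=O)/C(=C/c2ccccc2Cl)Oc2ccccc21` has no result in this assay, recorded as "not determined" (no result reported). Compound 3 `O=C1/C(=C/c2ccccc2Cl)Oc2ccccc2N1Cc1ccccc1` is likewise without a result, recorded as "not determined" (no result reported). So compound 1 stands alone as the only entry with any reading, and that reading is a limit.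

Compound 4 `Cc1cccc(C(=O)/C=C2\Nc3ccccc3OC2=O)c1` has not yet been tested. It differs from compound 1 in one place: 3-methylphenyl in place of 2-methylphenyl on a carbonyl carbon. Such a shift of a methyl group between positions on a ring usually leaves cytotoxicity within the ordinary scatter. The expected step from compound 1 to compound 4 is therefore a number no higher from compound 1 to compound 4 (the limit leaves the size open), essentially none beyond scatter. Compound 4 is expected to give about 1790000 nM, within 600000 nM to 5000000 nM, most likely again reported only as a limit.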

Compound 4, half-maximal cytotoxic concentration: > 1790000 nM
Compound 4: a limit, no number; the forecaster's own chance of this, stated with the estimate: 80%; the middle value lies on the limit itself.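

Compound 1 and compound 4 each give only a limit, not a number, in this assay, so no step between them can be read: the limit of > 1790000 nM in this assay, at which 2 of the 4 values shown sit.

The compounds shown leave open whether moving the methyl group on the ring changes cytotoxicity at all.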